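This account rests on a few compounds, and the source may have more. Where it says the series, first, only, none or still open, it means among the compounds named here.

Compound 1, `O=C(NCc1cc(Cl)ccc1-n1cnnn1)[C@@H]1C[C@@H]2C[C@@H]2N1C(=O)[C@H](O)Cc1ccccn1`, was examined in a functional assay on a cell-free system (plasma, Homo sapiens), with a stated time of 3 min (on this read-out lower numbers stand for stronger inhibition and higher numbers for weaker inhibition), where compound 1 gives 1000 nM. Among the three measured compounds its number is the second highest. Compound 3, `O=C(NCc1cc(Cl)ccc1-n1cnnn1)[C@@H]1CC=NN1C(=O)[C@H](O)C1CCCCC1`, gives 970 nM in this assay, a value that lies within the scatter of that of compound 1. Compound 2, `COC(C)(C)[C@@H](O)C(=O)N1N=CC[C@H]1C(=O)NCc1cc(Cl)ccc1-n1cnnn1`, gives 3700 nM, which stands beyond the scatter above compound 1.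

Compound 4, `O=C(NCc1cc(Cl)ccc1-n1cnnn1)[C@@H]1C[C@@H]2C[C@@H]2N1C(=O)[C@H](O)c1cccc(Cl)c1`, has not yet been measured. It differs from compound 1 in one place: 3-chlorophenyl in place of (pyridin-2-yl)methyl on a saturated chain carbon bound to a carbonyl carbon and an oxygen on a saturated carbon.

Among the compounds with values here, the only measured step that touches the same place is the one between compound 2 and compound 3, in which cyclohexyl replaced 1-methoxy-1-methylethyl on a saturated chain carbon bound to a carbonyl carbon and an oxygen on a saturated carbon, and which gave a 3.8-fold lower number from compound 2 to compound 3 (0.58 log units; beyond the scatter). That step concerns a different core and different groups, so it bears on the present change only loosely. Since that step was modest, a modest step is also expected here, most likely toward a lower number, but a result within the scatter of compound 1 cannot be ruled out.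

Compound 4 is therefore estimated at 600 nM in this assay, within a range from 200 nM to 2000 nM, which would mean an expected step of a 1.7-fold lower number from compound 1 to compound 4 (0.22 log units; within the scatter).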

Compound 4, half-maximal inhibitory concentration: 1000 nM
Compound 4: the middle estimate sits 1.7-fold (0.22 log units) below what was measured, within the range that was stated.
By their numbers in this assay, from the lowest: compounds 3, 1 and 4 (each within the scatter of the next); then compound 2.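

Within the data shown here, on the core of compound 1, in this assay, putting 3-chlorophenyl in place of (pyridin-2-yl)methyl on a saturated chain carbon bound to a carbonyl carbon and an oxygen on a saturated carbon gave no change at the digits printed from compound 1 to compound 4 (within the scatter), the first step at this place read on that core rather than on the core of compounds 2 and 3. The exchange keeps the count of 7 heavy atoms and one six-membered aromatic ring, yet swaps the ring nitrogen and its hydrogen-bond acceptor for a ring of carbon only that carries chlorine, and the read-out stays within the scatter, so this position tolerates that particular swap on this core. No supporting measurement is available to explain why the number holds.

The swap changes the ring atoms, the chlorine and the chain carbon of (pyridin-2-yl)methyl all at once, so the compounds shown cannot separate the contribution of each, and cyclohexyl remains untested on the core of compound 1. Going by these compounds, it also remains open how a primary amine, a carboxylic acid or a longer alkyl chain at this place would read out in this assay on this core.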